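A few compounds are considered here, and "the series" means these few. Any claim that something is new, unique, unknown or untested is made for them only; others in the source may bear on it.

Compound 1 `CN(C)Cc1ccc2oc(-c3ccccc3Cl)cc(=O)c2c1`: 36.2%
Compound 2 `NS(=O)(=O)c1ccc(NCc2ccc3oc(-c4ccccc4Cl)cc(=O)c3c2)cc1`: 32.2%

In a functional assay on the whole organism (strain Wistar albino) for inhibition, with Rattus norvegicus as the target, read by paw edema, with stated times of 30 min and 2 h, at a dose of 20 mg/kg by the oral route (on this read-out higher numbers stand for more inhibition at the one dose given (going by the name of the read-out) and lower numbers for less inhibition), compound 2 gives 32.2%. Compound 1 gives 36.2%, and the gap between these two numbers lies within the scatter of repeated measurements, so the two cannot be put in order on this read-out. Within the data shown here, no step between measured compounds that differ in one place is available, and neither compound carries the group that is changed next.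

Compound 3 `Cc1ccc(NCc2ccc3oc(-c4ccccc4Cl)cc(=O)c3c2)cc1` differs from compound 2 in one place: methyl in place of sulfamoyl on an aromatic carbon. Among the measured compounds shown here, with no measured step to lean on, the two numbers in hand suggest that such a change at this position is not expected to move the read-out beyond the scatter. The expected a number 0.2 percentage points lower from compound 2 to compound 3 (within the scatter) is accordingly put at about nothing. For compound 3 in this assay a value of 32% is estimated, with a range from 18% to 46%.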

Compound 3, a percentage reported as inhibition, in the whole organism at one dose (the size of the read-out at that dose, not a potency): 19.8%
Estimate against measurement, compound 3: 12.2 percentage points above; measured number inside the range.
By their numbers in this assay, from the lowest: compound 3; then compounds 2 and 1 (each within the scatter of the next).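

The exchange of sulfamoyl for methyl on this aromatic carbon is the first change shown to move the read-out in this assay: it gives a number 12.4 percentage points lower from compound 2 to compound 3 (beyond the scatter). The group at this position therefore matters, at least for this pair, and the 4-sulfamoylphenyl compound cannot be exchanged for the 4-methylphenyl one without a loss of inhibition at the one dose given. Compound 3 also stands apart from the dimethylamino compound, with a number 16.4 percentage points lower from compound 1 to compound 3 (beyond the scatter), although compound 1 and compound 2 themselves cannot be put in order.

Nothing available explains why the read-out falls with this change. As far as these compounds go, whether any group other than sulfamoyl would hold the read-out at this position, such as a carboxylic acid, an amine or a methoxy group, remains open.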